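The source may hold more compounds than are shown below. What is called first, only, known or untested is meant among the compounds shown, and "the series" means these compounds.

Measured so far in an ADME assay on L929 cells (Mus musculus) for antiproliferative activity, read by CCK-8 assay, with a stated time of 48 h; on this read-out lower numbers stand for stronger inhibition and higher numbers for weaker inhibition:
compound 1, `CC(C)CSc1n[nH]c(-n2[se]c3ccccc3c2=O)n1`, gives 33400 nM
compound 2, `O=c1c2ccccc2[se]n1-c1nc(SCc2ccc([N+](=O)[O-])cc2)n[nH]1`, gives 7430 nM

Of the two numbers in this assay, compound 2 holds the lower one; its nearest neighbour is compound 1, whose value is higher by a margin beyond the scatter, so the two are clearly distinct. No pair of these compounds differs in a single place, so no measured step is available to calibrate what a change on the benzyl ring does.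

Compound 3, `O=c1c2ccccc2[se]n1-c1nc(SCc2ccc(Cl)cc2)n[nH]1`, is the next member of the series. It differs from compound 2 in one place: chloro in place of nitro on an aromatic carbon. Both substituents sit on the same aromatic carbon, and the rest of the structure is unchanged. With no measured step of this kind in the set, the expectation is a step from compound 2 to compound 3 of modest size in this assay, either direction possible, and most likely not beyond the scatter; the estimate puts it at a 1.2-fold higher number from compound 2 to compound 3 (0.08 log units; within the scatter). Compound 3 is therefore expected to give about 9000 nM, within a range of 3000 nM to 30000 nM.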

Compound 3, half-maximal inhibitory concentration: 39500 nM
Compound 3: the middle estimate sits 4.4-fold (0.64 log units) below what was measured, outside the stated range (above it).
By their numbers in this assay, from the lowest: compound 2; then compounds 1 and 3 (each within the scatter of the next).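

Chloro in place of nitro on the aromatic carbon para to a large group gives the first measured step at this place in this assay, and it is not a silent change: the step is a 5.3-fold higher number from compound 2 to compound 3 (0.73 log units; beyond the scatter) and sets compound 2 apart from its chloro counterpart. Placing 4-chlorophenyl in place of isopropyl on the saturated chain carbon bound to a sulfur gives a 1.2-fold higher number from compound 1 to compound 3 (0.07 log units; within the scatter) with no separation, so the aromatic ring with chloro on it does not by itself set compound 3 apart from compound 1. Among these three compounds, the lower number is found only with nitro on the ring, in compound 2, and nothing at hand bears on the reason for this difference.

From the compounds shown here alone, whether the lower number is particular to nitro or would also appear with an amine, a nitrile or a carboxylic acid on the same aromatic carbon remains open. Also open, going by these compounds, are whether nitro would give the same result on another carbon of the ring, and whether a longer chain on the sulfur would differ from isopropyl.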